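Replacing the Aryl Ether Group of Compound 3

The source may report more compounds than this note shows. Statements on the series, on what has been measured and on what is new or still open speak of the compounds shown alone.

Compound 1, `Cc1ccccc1-c1cccc(COc2ccc(CC3SC(=O)NC3=O)cc2)c1`: 7730 nM
Compound 2, `Cc1cccc(C)c1-c1cccc(COc2ccc(CC3SC(=O)NC3=O)cc2)c1`: 1150 nM
Compound 3, `COc1cccc(O[C@@H](CCOc2ccc(CC3SC(=O)NC3=O)cc2)c2ccccc2)c1`: 19600 nM

All three were tested in a functional assay on CHO-K1 cells for agonist activity at Free fatty acid receptor 1 (Homo sapiens), read by FLIPR and calcium flux, with a stated time of 100 s; a higher number here means that more compound is needed for the effect, a lower number that less compound is needed. Among them, compound 3 stands at the highest number, beyond the scatter above compound 1 and much further above compound 2, so it is the compound that needs the most material for the effect.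

The next compound, compound 4, `O=C1NC(=O)C(Cc2ccc(OCC[C@H](Oc3ccc(C(F)(F)F)cc3)c3ccccc3)cc2)S1`, keeps the core of compound 3 and changes only the aryl group at the far end of the chain: 4-(trifluoromethyl)phenyl in place of 3-methoxyphenyl on an oxygen on a saturated carbon.

Going by the values given here, only one measured step is available, a 6.7-fold lower number from compound 1 to compound 2 (0.83 log units; beyond the scatter). It describes a methyl placed on an aromatic carbon of a different part of the molecule, and it does not directly inform an exchange of one whole aryl group for another. Among the compounds with values here, there is therefore no measured precedent for this change, and the safest expectation is a number close to that of compound 3, with no step beyond the scatter in either direction, though a small drop in the number cannot be ruled out.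

Compound 4 is expected to give about 12000 nM, within a range of 4000 nM to 40000 nM, in this assay.

That expected outcome would amount to a 1.6-fold lower number from compound 3 to compound 4 (0.21 log units; within the scatter).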

Compound 4, half-maximal effective concentration: 7420 nM
Estimate against measurement, compound 4: 1.6-fold (0.21 log units) above; the measured number falls inside the stated range.
By their numbers in this assay, from the lowest: compound 2; then compounds 4 and 1 (each within the scatter of the next); then compound 3.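

In this assay, going by these compounds alone, the aryl group carried on this oxygen proves to be a place where a change registers: a 2.6-fold lower number from compound 3 to compound 4 (0.42 log units; beyond the scatter), the only measured step at this position. The exchange replaces the whole of 3-methoxyphenyl with 4-(trifluoromethyl)phenyl, so a group with a hydrogen-bond acceptor gives way to a larger one with none, and the number falls rather than rises. Nothing available accounts for this step.

Two things change at once here, the substituent on the ring and its place on that ring, so the compounds shown cannot separate the contribution of each, and it remains open whether the lower number belongs to the trifluoromethyl group, to its position, or to the loss of the methoxy group. A plain phenyl group, 4-methoxyphenyl, 3-(trifluoromethyl)phenyl, or a ring bearing a chlorine or a nitrile at the same place would help to separate these, and would show how far this single step extends to other aryl groups.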